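Methyl for Fluoro on an Aryl Hydrazone: Expected Cytotoxicity

The source may hold more compounds than are shown below. What is called first, only, known or untested is meant among the compounds shown, and "the series" means these compounds.

compound 1, `CCOC(=O)N1CCC(=NNC(=O)c2ccc(Cl)cc2)CC1`: > 400000 nM in a toxicity assay on BJ cells (Homo sapiens) for cytotoxicity, read by MTT assay, with a stated time of 24 h (on this read-out lower numbers stand for stronger inhibition and higher numbers for weaker inhibition), a limit of that measurement
compound 2, `CCOC(=O)N1CCC(=NNC(=O)c2ccc(F)cc2)CC1`: > 400000 nM in this assay, likewise a limit

Compound 2 stands at a limit of this assay, not at a number. Compound 1 sits at a limit too, so the step that the two limits leave unreadable from compound 1 to compound 2 cannot be read. Both values rest at the limit of > 400000 nM in this assay, at which 2 of the 2 values shown sit. Compound 3, `CCOC(=O)N1CCC(=NNC(=O)c2ccc(C)cc2)CC1`, differs from compound 2 by methyl in place of fluoro on an aromatic carbon. For the measured compounds named here, no measured step bears on this change in a readable way, since a step that the two limits leave unreadable from compound 1 to compound 2 is itself hidden by the two limits. All the numbers show is that replacing chloro with fluoro on that aromatic carbon left the read-out at its limit. Compound 3 is therefore expected to stay at or near that limit, with a step of a number no higher from compound 2 to compound 3 (the limit leaves the size open) of no readable size. The estimate for compound 3 is 400000 nM, with an expected range from 150000 nM to 1000000 nM.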

Compound 3, half-maximal inhibitory concentration: > 400000 nM
Compound 3 was reported as a limit (the forecaster's own chance of this, stated with the estimate: 85%); the middle value sits exactly at the limit.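

In this assay compound 3 gives > 400000 nM as a limit, not a number. For the compounds shown here, no step among compound 1, compound 2 and compound 3 can be read. The compounds shown leave open how chloro, fluoro and methyl on that aromatic carbon compare in cytotoxicity.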